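The source may hold more compounds than are shown below. What is called first, only, known or untested is meant among the compounds shown, and "the series" means these compounds.

Measured so far in an ADME assay on TERT-RPE1 cells (Homo sapiens) for cytotoxicity, read by luminescence and ATP content, with a stated time of 48 h; on this read-out higher numbers stand for weaker inhibition and lower numbers for stronger inhibition:
Compound 1, `O=C1OCC(c2ccc(C(F)(F)F)cc2)=C1c1c[nH]c2ccccc12`: in this assay compound 1 gives 870 nM.
Compound 2, `CC(=O)OCC1(COC(C)=O)OC(=O)C(c2ccc(Br)cc2)=C1c1ccc(C)cc1`: in this assay compound 2 gives > 40000 nM, which is a limit of the assay and not a number.
Compound 3, `COc1ccc(C2=C(c3ccc(OC)c(OC)c3)C(CO)OC2=O)cc1`: in this assay compound 3 gives > 40000 nM, again a limit of the assay rather than a number.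

Compound 3 therefore stands not at a measured value but at the edge of what the assay reports; it shares this position with compound 2, as noted by the limit of > 40000 nM in this assay, at which 2 of the 3 values shown sit, while compound 1 alone returns a number. No pair among these three differs in a single place, so no measured step connects them, and nothing can be said about the size of any one change in this set.

Compound 4, `COc1ccc(C2=C(c3ccc(OC)c(OC)c3)C(CO)(CO)OC2=O)cc1`, is not yet measured. It differs from compound 3 by hydroxymethyl in place of hydrogen on a saturated ring carbon. For the measured compounds named here, with no measured step to lean on and compound 3 already at the limit, the expected step from compound 3 to compound 4 is none beyond the scatter, and it is expected that a step that the limit leaves unreadable from compound 3 to compound 4 is what the data will show. Compound 4 is therefore estimated at 60000 nM, within a range from 20000 nM to 200000 nM, with the assay most likely again reporting only a limit.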

Compound 4, half-maximal inhibitory concentration: > 40000 nM
Compound 4: only a limit was reported; the forecaster's own chance of this, stated with the estimate: 85%; the middle value is on the limit's open side.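

In this assay compound 4 gives > 40000 nM, which is a limit of the assay and not a number. Compound 3 also stands at a limit, so no step between compound 3 and compound 4 can be read: the limit of > 40000 nM in this assay, at which 3 of the 4 values shown sit.

The compounds shown leave open whether hydroxymethyl in place of hydrogen on a saturated ring carbon changes the read-out at all.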